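This account rests on a few compounds, and the source may have more. Where it says the series, first, only, none or still open, it means among the compounds named here.

Three compounds share one core and differ only in the group attached to the aromatic nitrogen. Compound 1 `Cc1cccc(-n2cc(COC(=O)c3cc4ccccc4[nH]3)nn2)c1C` gives 15300 nM in an ADME assay on HEK293 cells (Homo sapiens) for cytotoxicity, read by MTT assay, with a stated time of 48 h (a higher number here means a weaker inhibitor, a lower number a stronger inhibitor), compound 2 `Cc1cc(C)cc(-n2cc(COC(=O)c3cc4ccccc4[nH]3)nn2)c1` gives 12500 nM, and compound 3 `CCCCc1ccc(-n2cc(COC(=O)c3cc4ccccc4[nH]3)nn2)cc1` gives 24200 nM. Among the measured compounds shown here, the single one-place step, a 1.2-fold lower number from compound 1 to compound 2 (0.09 log units; within the scatter), falls within the scatter, and the three numbers lie within the scatter of one another, so compound 3 stands apart from neither. Compound 4 `COc1ccc(-n2cc(COC(=O)c3cc4ccccc4[nH]3)nn2)cc1` differs from compound 3 by methoxy in place of butyl on an aromatic carbon. For the measured compounds named here, no measured step touches this position, so there is nothing to suggest a shift beyond the scatter; the expected change is a 1.3-fold lower number from compound 3 to compound 4 (0.13 log units; within the scatter). Compound 4 is therefore estimated at 18000 nM, with a range from 8000 nM to 40000 nM.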

Compound 4, half-maximal inhibitory concentration: 42500 nM
Beside the measured number, compound 4's estimate is 2.4-fold (0.37 log units) below it; the measured number lies above the stated range.
By their numbers in this assay, from the lowest: compounds 2, 1, 3 and 4 (each within the scatter of the next, the first and the last beyond it).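

In this assay, methoxy in place of butyl on the aromatic carbon comes to a 1.8-fold higher number from compound 3 to compound 4 (0.24 log units; within the scatter), so this direct change alone shows no clear shift. Among the compounds shown here, the 4-methoxyphenyl group does give the first steps beyond the scatter when it replaces a dimethylphenyl group, with a 3.4-fold higher number from compound 2 to compound 4 (0.53 log units; beyond the scatter) and a 2.8-fold higher number from compound 1 to compound 4 (0.44 log units; beyond the scatter), though both steps are modest. No supporting measurement explains these differences. As far as these compounds go, it remains open where an amine or a carboxylic acid on this aromatic carbon would fall, and whether a chain longer than butyl would give a different number.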